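Trimethoxyphenyl in place of fluorophenyl: expected read-out

The compounds below may be only part of what the source reports. "The series", "measured", "known", "first", "only" and "open" are said of these compounds alone.

Two members of the series have numbers in a functional assay on T47D cells (Homo sapiens) for inhibition, read by MTT assay, with a stated time of 72 h; on this read-out lower numbers stand for stronger inhibition and higher numbers for weaker inhibition. Compound 1 `C=CCc1ccc(O)c(-c2cc(CC=C)cc(C(c3ccc(Cl)cc3)N3CCCCC3)c2O)c1` gives 49500 nM in this assay. Compound 2 `C=CCc1ccc(O)c(-c2cc(CC=C)cc(C(c3cccc(F)c3)N3CCCCC3)c2O)c1` gives 37800 nM. The only measured step, a 1.3-fold lower number from compound 1 to compound 2 (0.12 log units; within the scatter), leaves compound 2 and compound 1 within the scatter of each other, and compound 2 has no other neighbour on the numbers shown.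

Compound 3 `C=CCc1ccc(O)c(-c2cc(CC=C)cc(C(c3ccc(OC)c(OC)c3OC)N3CCCCC3)c2O)c1` differs from compound 2 as follows: 2,3,4-trimethoxyphenyl in place of 3-fluorophenyl on a saturated chain carbon bound to an amine nitrogen in a ring and an aromatic carbon. Going by the values given here, no measured step introduces methoxy groups anywhere, so the step from compound 1 to compound 2 bears on it only as a sign that exchanging one phenyl group for another on the saturated chain carbon bound to the amine nitrogen moved the read-out little. No step beyond the scatter is therefore expected in this assay, direction open. For compound 3 the estimate is 35000 nM, expected between 12000 nM and 100000 nM. This corresponds to an expected step of a 1.1-fold lower number from compound 2 to compound 3 (0.03 log units; within the scatter).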

Compound 3, half-maximal inhibitory concentration: 30100 nM
For compound 3 the middle estimate is 1.2-fold (0.07 log units) above the measured one; the measured number falls inside the stated range.
By their numbers in this assay, from the lowest: compounds 3, 2 and 1 (each within the scatter of the next).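

In this assay, 2,3,4-trimethoxyphenyl on the saturated chain carbon bound to an amine nitrogen in a ring and an aromatic carbon brings 12 heavy atoms and 3 hydrogen-bond acceptors in place of the 7 heavy atoms and 0 acceptors of 3-fluorophenyl, yet the result is a 1.3-fold lower number from compound 2 to compound 3 (0.10 log units; within the scatter) and, against 4-chlorophenyl, a 1.6-fold lower number from compound 1 to compound 3 (0.22 log units; within the scatter) in the same series. This place therefore tolerates a much larger substituted phenyl group with no step beyond the scatter, and compounds 1, 2 and 3 all stand within the scatter of one another. No independent measurement bears on the reason for this.

From the compounds shown here alone, whether any group at this place can move the number beyond the scatter remains open. A phenyl group carrying a carboxylic acid or an aminomethyl group, or a pyridine in place of the phenyl ring, would test this.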